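The source may hold more compounds than are shown below. What is called first, only, known or untested is meant among the compounds shown, and "the series" means these compounds.

Compound 1, `COc1cccc(C2CCc3nc[nH]c3C2)c1`, and compound 2, `Clc1cccc(C2CCc3nc[nH]c3C2)c1`, share one core and were both tested in a functional assay on CHO cells for agonist activity at Alpha-1D adrenergic receptor (Homo sapiens), read by FLIPR and calcium flux; on this read-out higher numbers stand for an effect only at larger amounts of compound and lower numbers for an effect already at smaller amounts. In this assay compound 1 gives > 10000 nM, which is a limit of the assay and not a number. Compound 2 likewise gives > 10000 nM in this assay, again a limit rather than a number. The change from compound 1 to compound 2 is chloro in place of methoxy on an aromatic carbon, and its step in this assay is a step that the two limits leave unreadable from compound 1 to compound 2; because both values sit at the limit of > 10000 nM in this assay, at which 2 of the 3 values shown sit, the size of that step cannot be read.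

Compound 3, `COc1ccccc1C1Cc2nccn2C1`, rests on a different core; the difference between the two cores is not broken down here. For compound 3 in this assay the record is "not determined" (no result reported), so no number stands for it. Compound 4, `Clc1ccccc1C1Cc2nccn2C1`, has not yet been measured in this assay. It differs from compound 3 by chloro in place of methoxy on an aromatic carbon, the same kind of change as that from compound 1 to compound 2, though here the place is ortho to a group of 8 heavy atoms rather than meta to a group of 9 heavy atoms.

Among the compounds with values here, nothing measured tells how the two cores compare, and the one measured step is unreadable. Compound 4 is therefore expected to give about 15000 nM in this assay, with an estimated range from 2000 nM to 60000 nM. That expectation rests on compound 1 and compound 2, whose values both sit at the limit of > 10000 nM in this assay, at which 2 of the 3 values shown sit, and on the step that the two limits leave unreadable from compound 1 to compound 2, which gives no hint of potency.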

Compound 4, half-maximal effective concentration: 364 nM
The estimate for compound 4 lay 41-fold (1.61 log units) above the measured number; the whole stated range lies above it.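

In this assay compound 4 gives 364 nM, but compound 3 has no reported result, so no new step can be read from compound 3 to compound 4. The compounds shown leave open what chloro in place of methoxy does on either core and how the two cores compare, with compound 1 and compound 2 both resting at a limit: the limit of > 10000 nM in this assay, at which 2 of the 4 values shown sit.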